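One Added Methyl on a Compound Sitting at a Limit

The compounds below may be only part of what the source reports. "The series", "measured", "known", "first", "only" and "open" are said of these compounds alone.

In an ADME assay on L02 cells (Homo sapiens) for cytotoxicity, read by MTT assay, with a stated time of 72 h (a lower number here means a stronger inhibitor, a higher number a weaker inhibitor), compound 2 (`C/C=C/C(=O)Nc1cccc(Oc2nc(Nc3cccc(OC)c3)nc3c2CSCC3)c1`) reads > 50000 nM and this is a limit of the assay and not a number. Compound 1 (`CC/C=C/C(=O)Nc1cccc(Oc2nc(Nc3ccn(C)n3)nc3c2CSCC3)c1`) reads > 50000 nM and this too is a limit. So the whole picture so far is the limit of > 50000 nM in this assay, at which 2 of the 2 values shown sit, and no exact value exists for either compound.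

Compound 3 (`CC/C=C/C(=O)Nc1cccc(Oc2nc(Nc3cccc(OC)c3)nc3c2CSCC3)c1`) differs from compound 2 in one place: methyl in place of hydrogen on a saturated chain carbon bound to a double-bonded chain carbon. A methyl takes the place of a hydrogen on a saturated chain carbon bound to a double-bonded chain carbon, which turns prop-1-en-1-yl into but-1-en-1-yl. Compound 1 already carries the (but-1-en-1-yl)carbonyl group, though it differs elsewhere, and its > 50000 nM is again a limit.

For the measured compounds named here, no step between measured compounds is available as a guide, so in this assay no change beyond the usual scatter is expected, in either direction. The expected step is a step that the limit leaves unreadable from compound 2 to compound 3 and the assay may well report only a limit again. Compound 3 is estimated at 60000 nM with an expected range from 30000 nM to 120000 nM in this read-out.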

Compound 3, half-maximal inhibitory concentration: > 50000 nM
Compound 3 ended at the assay's limit; the forecaster's own chance of this, stated with the estimate: 85%; the middle value lies beyond the limit too.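

For the compounds shown here, no step to compound 3, whether from compound 1 or from compound 2, can be read, because all three compounds stop at the same limit in this assay: the limit of > 50000 nM in this assay, at which 3 of the 3 values shown sit. The compounds shown leave open the exact value of each one, and whether the added methyl, or 3-methoxyphenyl in place of 1-methyl-1H-pyrazol-3-yl, changes the reading at all.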